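This account rests on a few compounds, and the source may have more. Where it says the series, first, only, none or still open, it means among the compounds named here.

In a functional assay on the whole organism (Myocardium) with Canis familiaris (Canis lupus familiaris) as the target, at a dose of 8.75 mg/kg by the intravenous route (on this read-out higher numbers stand for an effect only at larger amounts of compound and lower numbers for an effect already at smaller amounts), compound 1 `Cc1nc(O)nc2cc(Cl)c(Cl)cc12` gives only a limit of the assay, > 8.75 mg/kg, and not a number. Among the measured compounds shown here, compound 2 `CCc1nc(O)nc2cc(OC)c(OC)cc12` gives 3.4 mg/kg, so it holds the only actual number so far and offers the one firm starting point. Compound 3 `COc1cc2nc(O)nc(-c3ccccc3)c2cc1OC` has phenyl in place of ethyl on an aromatic carbon of compound 2: phenyl in place of ethyl on an aromatic carbon. For the measured compounds named here, no measured pair shows a change of this kind, so the expected step of a 1.5-fold higher number from compound 2 to compound 3 (0.17 log units; within the scatter) is a small one toward larger doses, not beyond the usual scatter. For compound 3 the estimated dose is 5 mg/kg, with a range from 1.5 mg/kg to 15 mg/kg.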

Compound 3, dose for half-maximal effect: 4.1 mg/kg
Estimate against measurement, compound 3: 1.2-fold (0.09 log units) above; the range from low to high includes it.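

In this assay, putting phenyl in place of ethyl on this aromatic carbon, next to the ring nitrogen, gives a 1.2-fold higher number from compound 2 to compound 3 (0.08 log units; within the scatter). This is the first pair shown that differs in one place, and it shows that this much larger ring group leaves the dose for half-maximal effect within the scatter of the ethyl compound. Nothing measured here explains this result.

From the compounds shown here alone, whether an amine, a carboxylic acid or a longer chain at this position would read the same stays open. Compound 1 gives only a limit of the assay, > 8.75 mg/kg, and offers no comparison.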